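Swapping an Amine Chain for a Triazolyl Diol

The source may report more compounds than this note shows. Statements on the series, on what has been measured and on what is new or still open speak of the compounds shown alone.

Of the compounds shown here, three sharing one core have been measured in a functional assay on SH-SY5Y cells (Homo sapiens) for cytotoxicity, read by MTT assay, with a stated time of 72 h; on this read-out higher numbers stand for weaker inhibition and lower numbers for stronger inhibition. Compound 3 `CN1CCN(CCCCn2c3c(c4ccccc42)C(=O)c2c[n+]([O-])c4ccccc4c2C3=O)CC1` gives 100 nM and stands lowest of the three numbers, though compound 1 `O=C1c2c[n+]([O-])c3ccccc3c2C(=O)c2c1c1ccccc1n2Cc1cn([C@@H]2C[C@H](O)[C@@H](CO)O2)nn1`, with 150 nM, lies within the scatter of it, while compound 2 `O=C1c2c[n+]([O-])c3ccccc3c2C(=O)c2c1c1ccccc1n2Cc1cn([C@@H]2O[C@H](CO)[C@@H](O)[C@H](O)[C@H]2O)nn1` gives 880 nM. Among the compounds with values here, the only step between measured compounds is a 5.9-fold higher number from compound 1 to compound 2 (0.77 log units; beyond the scatter), a change of sugar on the triazole. Compound 4 `O=C1c2c[n+]([O-])c3ccccc3c2C(=O)c2c1c1ccccc1n2Cc1cn(C[C@H](O)CO)nn1` differs from compound 3 by 1-(2,3-dihydroxypropyl)-1H-1,2,3-triazol-4-yl in place of 3-(4-methylpiperazin-1-yl)propyl on a saturated chain carbon bound to an aromatic nitrogen. Within the data shown here, no measured step covers this exchange; compound 1 and compound 3 show that a triazolylmethyl carrier and the amine chain give numbers within the scatter of each other. Compound 4 is therefore expected to give about 200 nM, between 80 nM and 600 nM, a step of a 2.0-fold higher number from compound 3 to compound 4 (0.30 log units; within the scatter).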

Compound 4, half-maximal inhibitory concentration: > 1000 nM
Compound 4 gave a limit, no number; the forecaster's own chance of this, stated with the estimate: 3%; middle value at least 5.0-fold (0.69 log units) from the limit.
By their numbers in this assay, from the lowest: compounds 3 and 1 (each within the scatter of the next); then compound 2. At a limit, above all of these: compound 4.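

In this assay compound 4 stands at a limit of the assay, not at a number: the limit of > 1000 nM in this assay, at which 1 of the 4 values shown sits. The triazole carrier therefore does not by itself keep the number near that of the amine chain, as 1-(2,3-dihydroxypropyl)-1H-1,2,3-triazol-4-yl in place of 3-(4-methylpiperazin-1-yl)propyl gives an at least 10-fold higher number from compound 3 to compound 4 (1.00 log units; beyond the scatter) on a saturated chain carbon bound to an aromatic nitrogen. What the triazole carries also counts, with 2,3-dihydroxypropyl in place of 4-hydroxy-5-(hydroxymethyl)oxolan-2-yl giving an at least 6.6-fold higher number from compound 1 to compound 4 (0.82 log units; beyond the scatter) here, whereas 2,3-dihydroxypropyl in place of 3,4,5-trihydroxy-6-(hydroxymethyl)oxan-2-yl gives an at least 1.1-fold higher number from compound 2 to compound 4 (0.05 log units; that floor lies within the scatter) here. As far as these compounds go, whether a triazole bearing a 4-methylpiperazine would stay close to compound 3 remains open, as does the effect of a longer chain on the triazole.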